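The source may hold more compounds than are shown below. What is called first, only, known or untested is meant among the compounds shown, and "the series" means these compounds.

Measured compounds:
Compound 1, `CC1=NC(c2cn(S(=O)(=O)c3ccc(F)cc3)c3ccc(C)cc23)CN1`: 9400 nM
Compound 2, `CC1=NC(c2cn(S(=O)(=O)c3cccc(Cl)c3)c3ccc(C)cc23)CN1`: 30000 nM
Compound 3, `CC1=NC(c2cn(S(=O)(=O)c3ccccc3C#N)c3ccc(C)cc23)CN1`: 6700 nM

All three were tested in an assay on isolated protein for inhibition of kallikrein-7 (Homo sapiens), read by fluorescence, with stated times of 10 min and 30 min; on this read-out higher numbers stand for weaker inhibition and lower numbers for stronger inhibition. Compound 3 gives the lowest number of the three, but its gap to compound 1 is small, a 1.4-fold lower number from compound 1 to compound 3 (0.15 log units; within the scatter), while its gap to compound 2 is clearer, a 4.5-fold lower number from compound 2 to compound 3 (0.65 log units; beyond the scatter). Compound 4, `CC1=NC(c2cn(S(=O)(=O)c3c(Cl)cccc3Cl)c3ccc(C)cc23)CN1`, has not yet been measured. It differs from compound 3 in one place: 2,6-dichlorophenyl in place of 2-cyanophenyl on a sulfonyl sulfur. The measured steps that bear on this are the three exchanges of the aryl group on the sulfonyl sulfur: a 3.2-fold higher number from compound 1 to compound 2 (0.50 log units; beyond the scatter), a 1.4-fold lower number from compound 1 to compound 3 (0.15 log units; within the scatter) and a 4.5-fold lower number from compound 2 to compound 3 (0.65 log units; beyond the scatter). They show that swapping one substituted phenyl for another at this position can move the number by a modest amount in either direction, yet none of them involves two chlorines, so the direction for compound 4 is uncertain and the range must be wide. The step expected here is a 1.5-fold higher number from compound 3 to compound 4 (0.17 log units; within the scatter), leaning toward a somewhat higher number. Compound 4 is estimated at 10000 nM, between 3000 nM and 40000 nM.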

Compound 4, half-maximal inhibitory concentration: 14000 nM
For compound 4 the middle estimate is 1.4-fold (0.15 log units) below the measured one; the range from low to high includes it.
By their numbers in this assay, from the lowest: compounds 3, 1 and 4 (each within the scatter of the next, the first and the last beyond it); then compound 2.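

In this assay, for the compounds shown here, a phenyl ring carrying two chlorines on the sulfonyl sulfur gives a number inside the span already set by the earlier compounds, so this new substitution pattern does not extend the range seen at this position. The 2,6-dichlorophenyl group gives a lower number than 3-chlorophenyl (a 2.1-fold lower number from compound 2 to compound 4 (0.33 log units; beyond the scatter)) and a higher number than 2-cyanophenyl (a 2.1-fold higher number from compound 3 to compound 4 (0.32 log units; beyond the scatter)), while it cannot be told apart from 4-fluorophenyl (a 1.5-fold higher number from compound 1 to compound 4 (0.17 log units; within the scatter)). Nothing available explains why these groups differ. 

On these data alone, all four groups are substituted phenyl rings, so it remains open how the number would respond to a simple alkyl chain on the sulfur, or to a phenyl ring bearing an amine or a carboxylic acid. As far as these compounds go, all four compounds also share one core, so whether these steps would hold on another core is unknown.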